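Pyrrolidinylcarbonyl Replaces Methylsulfanyl on the Aryl Ring

A few compounds are considered here, and "the series" means these few. Any claim that something is new, unique, unknown or untested is made for them only; others in the source may bear on it.

Three compounds share one core and differ only in the group on a six-membered aromatic ring of carbon only. In a functional assay on HEK293 cells for antagonist activity at transient receptor potential cation channel subfamily V member 1 (Homo sapiens), read by calcium flux (on this read-out higher numbers stand for weaker inhibition and lower numbers for stronger inhibition), compound 1 `FC(F)(F)c1ccc(Nc2ncnc3sc(Nc4c(Cl)cccc4Cl)nc23)cc1` gives 12 nM; compound 2 `Cc1ccc(Nc2ncnc3sc(Nc4c(Cl)cccc4Cl)nc23)cc1` gives 33 nM; compound 3 `CSc1ccc(Nc2ncnc3sc(Nc4c(Cl)cccc4Cl)nc23)cc1` gives 96 nM. Compound 3 therefore has the highest number of the three, as shown by a 2.9-fold higher number from compound 2 to compound 3 (0.46 log units; beyond the scatter) and by an 8.0-fold higher number from compound 1 to compound 3 (0.90 log units; beyond the scatter). Compound 4 `O=C(c1ccc(Nc2ncnc3sc(Nc4c(Cl)cccc4Cl)nc23)cc1)N1CCCC1` carries the change ((pyrrolidin-1-yl)carbonyl in place of methylsulfanyl on an aromatic carbon). Among the measured compounds shown here, no measured step exchanges a group on this ring for an amide of this kind; the steps of a 2.8-fold higher number from compound 1 to compound 2 (0.44 log units; beyond the scatter), a 2.9-fold higher number from compound 2 to compound 3 (0.46 log units; beyond the scatter) and an 8.0-fold higher number from compound 1 to compound 3 (0.90 log units; beyond the scatter) show only that swapping small groups at this position moves the number in this assay by modest amounts. Compound 4 is expected to show a step of a 1.0-fold higher number from compound 3 to compound 4 (0.02 log units; within the scatter), which should lie within the scatter, though the direction is uncertain. The estimate for compound 4 in this assay is 100 nM, in a range from 30 nM to 350 nM.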

Compound 4, half-maximal inhibitory concentration: > 5000 nM
Compound 4 gave a limit, no number; the forecaster's own chance of this, stated with the estimate: 5%; middle value at least 50-fold (1.69 log units) away from the limit.
By their numbers in this assay, from the lowest: compound 1; then compound 2; then compound 3. At a limit, above all of these: compound 4.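

In this assay compound 4 gives a limit and not a number: the limit of > 5000 nM in this assay, at which 1 of the 4 values shown sits. The steps to it are of another order than those among the three small groups, and each is large: an at least 52-fold higher number from compound 3 to compound 4 (1.71 log units; beyond the scatter) and an at least 150-fold higher number from compound 2 to compound 4 (2.18 log units; beyond the scatter) and also an at least 410-fold higher number from compound 1 to compound 4 (2.61 log units; beyond the scatter). So this position, on which trifluoromethyl, methyl and methylsulfanyl differ only modestly, does not accept every group, and (pyrrolidin-1-yl)carbonyl marks a change that the earlier compounds gave no sign of.

Going by these compounds, whether the loss goes with the carbonyl or with the pyrrolidine ring stays open, as does the outcome with a primary carboxamide, a carboxylic acid or an open-chain amine here. On these data alone, with a limit at one end, the full size of these steps also stays unknown.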